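The compounds below may be only part of what the source reports. "The series", "measured", "known", "first", "only" and "open" are said of these compounds alone.

Working notes on the series.

Among the compounds with values here, compound 1 `COc1cc(-c2nnc(SCc3ccccc3Cl)n2/N=C/c2ccccc2)cc(OC)c1OC` carries the 2-chlorobenzyl group on the sulfur with an unsubstituted benzaldimine; in a functional assay on HepG2 cells (Homo sapiens) for cytotoxicity, read by MTT assay, with a stated time of 48 h (a higher number here means a weaker inhibitor, a lower number a stronger inhibitor), compound 1 gives 31700 nM, the only numbered value in the set. Compound 2 `COc1ccc(/C=N/n2c(SC)nnc2-c2cc(OC)c(OC)c(OC)c2)c(OC)c1` reaches in this assay only a limit, > 200000 nM. Compound 3 `COc1ccc(/C=N/n2c(SCc3ccc(F)cc3)nnc2-c2cc(OC)c(OC)c(OC)c2)c(OC)c1` likewise returns in this assay only a limit, > 200000 nM. Within the data shown here, compound 3 therefore stands at the limit of > 200000 nM in this assay, at which 2 of the 3 values shown sit, together with compound 2, and the one step measured on the sulfur substituent, a step that the two limits leave unreadable from compound 2 to compound 3, cannot be sized because both ends sit at the limit.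

Compound 4 `COc1ccc(/C=N/n2c(SCc3ccccc3Cl)nnc2-c2cc(OC)c(OC)c(OC)c2)c(OC)c1` differs from compound 3 by 2-chlorophenyl in place of 4-fluorophenyl on a saturated chain carbon bound to a sulfur. Compound 1 holds the same 2-chlorobenzyl group but differs from compound 4 at the benzaldimine as well, so no single-point step connects them; its value and the limit of compound 3 are simply what is shown. Since the exchange of hydrogen for 4-fluorophenyl at this position left compound 2 and compound 3 both at the limit, a further exchange of the aryl is expected to give at most a modest change. Compound 4 is estimated at 150000 nM, within 30000 nM to 600000 nM, the expected step being an at least 1.3-fold lower number from compound 3 to compound 4 (0.12 log units; that floor lies within the scatter), most likely again only a limit.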

Compound 4, half-maximal inhibitory concentration: > 200000 nM
Compound 4 ended at the assay's limit (the forecaster's own chance of this, stated with the estimate: 60%); at least 1.3-fold (0.12 log units) between middle value and limit.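

The sulfur substituent still gives no size in this assay: the steps among compound 2, compound 3 and compound 4 cannot be read, and swapping 4-fluorobenzyl for 2-chlorobenzyl adds a third compound to the same limit: the limit of > 200000 nM in this assay, at which 3 of the 4 values shown sit.

Within the data shown here, what is new is the first readable step in the set, and it lies at the imine end, not on the sulfur: with 2-chlorobenzyl held in place, 2,4-dimethoxyphenyl in place of phenyl on a carbon with a double bond to nitrogen gives an at least 6.3-fold higher number from compound 1 to compound 4 (0.79 log units; beyond the scatter). Among these compounds, the value of compound 4 is a limit, so this step gives only a minimum size, but it places the one measurable change in the set at this aryl group.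

Whether the sulfur substituent has any readable effect remains open, as all three sulfur substituents paired with 2,4-dimethoxyphenyl end at the limit, and only 2-chlorobenzyl is shown with phenyl. Also open, from the compounds shown here alone, is how an amine or a carboxylic acid on the aryl group at the imine would read in this assay.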